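The compounds below may be only part of what the source reports. "The series", "measured", "known", "first", "only" and "open" are said of these compounds alone.

Working notes on a set of compounds that share one core and were tested for T-type channel inhibition. Compound 1 `Cc1nc(-c2ccccc2)c(CNCCN2CCN(C(c3ccccc3)c3ccccc3)CC2)o1` carries a benzhydryl-substituted ring at the end of the chain; compound 2 `CCCc1nc(-c2ccccc2)c(CNCCCN2CCN(c3ccc(OC)cc3)CC2)o1` and compound 3 `CCCc1nc(-c2ccccc2)c(CNCCN2CCN(c3cccc(OC)c3)CC2)o1` instead carry a methoxyphenyl group on that ring nitrogen. In an assay on HEK293 cells for inhibition of Voltage-dependent T-type calcium channel subunit alpha-1G (Homo sapiens), read by fluorescence, tested at 10 uM (on this read-out lower numbers stand for less inhibition and higher numbers for more inhibition at the one concentration tested (going by the name of the read-out)), compound 1 gives 57.3%. In this assay compound 2 gives 42.1%, which is the second highest of the three numbers. Compound 3 gives 40.2% in this assay; the numbers of compound 2 and compound 3 lie within the usual scatter of each other, so no order between them can be claimed. Compound 1 and compound 2 differ by more than the scatter, so compound 1 does sit higher than compound 2 on this read-out.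

The next compound in the series is compound 4 `CCCc1nc(-c2ccccc2)c(CNCCCN2CCN(c3ccccc3C(F)(F)F)CC2)o1`. It differs from compound 2 in one place:

2-(trifluoromethyl)phenyl in place of 4-methoxyphenyl on an amine nitrogen in a ring

For the measured compounds named here, no two measured compounds differ only by this change, so nothing in the present numbers tells how it acts on this assay. A step of modest size is expected, as likely upward as downward, and it may not exceed the scatter. Compound 4 is estimated to give about 48% in this assay, with a plausible range from 30% to 66%. This estimate implies a step of a number 5.9 percentage points higher from compound 2 to compound 4 (within the scatter).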

Compound 4, a percentage reported as inhibition, at one concentration (the size of the read-out at that concentration, not a potency): 45%
Compound 4: the middle estimate sits 3 percentage points above what was measured; the range from low to high includes it.
By their numbers in this assay, from the lowest: compounds 3, 2 and 4 (each within the scatter of the next); then compound 1.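

In this assay, for the compounds shown here, 2-(trifluoromethyl)phenyl in place of 4-methoxyphenyl on an amine nitrogen in a ring gives a number 2.9 percentage points higher from compound 2 to compound 4 (within the scatter), the first step that can be read for a single change. The two groups differ in heavy-atom count and element make-up, and only the leaving group counts a hydrogen-bond acceptor, yet this exchange sets no order between the two compounds on this read-out. No separate measurement is available to explain the size of this step.

A single exchange at this position leaves open whether a different substituent on the phenyl ring, such as a nitrile or a carboxylic acid, would give a step beyond the scatter. It also leaves open whether a benzhydryl group at this position, tested on the same propyl-substituted core and chain as compound 4, would stand apart from the aryl groups, since compound 1 differs from the other compounds in more than one place.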